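Piperidinyl for tetrahydroisoquinolinyl on the aminopyrimidine

The compounds below may be only part of what the source reports. "The series", "measured", "known", "first", "only" and "open" are said of these compounds alone.

Measured compounds:
compound 1, `c1cc(N2CCCCC2)nc(Nc2ccc(Oc3ncnc4sccc34)cc2)n1`, 66.3%
compound 2, `CN(c1ccc(Oc2ncnc3ccsc23)cc1)c1nccc(N2CCCCC2)n1`, 66.2%
compound 3, `c1ccc2c(c1)CCN(c1ccnc(Nc3ccc(Oc4ncnc5ccsc45)cc3)n1)C2`, 40.9%

In a functional assay on HCT-116 cells (Homo sapiens) for inhibition, read by MTT assay, with a stated time of 72 h, tested at 20 uM (on this read-out higher numbers stand for more inhibition at the one concentration tested (going by the name of the read-out) and lower numbers for less inhibition), compound 3 gives 40.9%, the lowest of the three numbers. Its nearest neighbour is compound 2 at 66.2%, a gap beyond the scatter, and the furthest is compound 1 at 66.3%, also beyond the scatter. Compound 1 and compound 2 lie within the scatter of each other, so no order is drawn between them.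

Compound 4, `c1cc(N2CCCCC2)nc(Nc2ccc(Oc3ncnc4ccsc34)cc2)n1`, has not been measured. It differs from compound 3 in one place: piperidin-1-yl in place of 1,2,3,4-tetrahydroisoquinolin-2-yl on an aromatic carbon on an aromatic carbon of a six-membered aromatic ring with 2 nitrogen, next to the ring nitrogen, meta to a large group, opposite the ring nitrogen.

A step upward, beyond the scatter, is expected in this assay for this change. Compound 4 is expected to give 62%, within 45% to 78%, because compound 1 at 66.3% and compound 2 at 66.2% both sit well above compound 3. The expected step of a number 21.1 percentage points higher from compound 3 to compound 4 (beyond the scatter) is an estimate only, resting on three measured compounds.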

Compound 4, a percentage reported as inhibition, at one concentration (the size of the read-out at that concentration, not a potency): 61.5%
Beside the measured number, compound 4's estimate is 0.5 percentage points above it, and the stated range covers the measured number.
By their numbers in this assay, from the lowest: compound 3; then compounds 4, 2 and 1 (each within the scatter of the next).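

In this assay, among the compounds shown here, piperidin-1-yl in place of 1,2,3,4-tetrahydroisoquinolin-2-yl gives a number 20.6 percentage points higher from compound 3 to compound 4 (beyond the scatter) as the one comparison that isolates this position, and it ties the low number of compound 3 to that group rather than to the rest of the structure. With piperidin-1-yl in place, neither other change separates from the scatter: hydrogen in place of methyl on the nitrogen gives a number 4.7 percentage points lower from compound 2 to compound 4 (within the scatter) and the exchange of the group on the oxygen gives a number 4.8 percentage points lower from compound 1 to compound 4 (within the scatter) in this comparison. No accompanying measurement bears on why the group matters.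

On these data alone, whether a morpholine, a 4-methylpiperazine or a dimethylamino group at this position would match piperidin-1-yl remains open. Also open, as far as these compounds go, is whether the methyl on the nitrogen or the exchanged group on the oxygen would read the same with 1,2,3,4-tetrahydroisoquinolin-2-yl present.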